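The compounds below may be only part of what the source reports. "The series", "measured", "known", "first", "only" and "open" are said of these compounds alone.

Measured so far in an ADME assay on J774 cells (Mus musculus, strain BALB/c) for cytotoxicity, read by resazurin assay, with a stated time of 72 h; on this read-out lower numbers stand for higher toxicity in this test and higher numbers for lower toxicity in this test:
compound 1 `CC(/C=N/Nc1ccc([N+](=O)[O-])cc1)=N\NC(=O)c1ccccc1O`, where compound 1 gives 29500 nM.
compound 2 `COc1cc(C(=O)N/N=C(C)/C=N/Nc2ccc([N+](=O)[O-])cc2)ccc1O`, where compound 2 gives only a limit, > 100000 nM.

Compound 2 thus stands at the limit (the limit of > 100000 nM in this assay, at which 1 of the 2 values shown sits), with no number of its own. Going by the values given here, the one measured step, an at least 3.3-fold higher number from compound 1 to compound 2 (0.53 log units; beyond the scatter), moved the number up to that limit. Compound 3 `CC(/C=N/Nc1ccc([N+](=O)[O-])cc1)=N\NC(=O)c1ccc([N+](=O)[O-])cc1` differs from compound 2 by 4-nitrophenyl in place of 4-hydroxy-3-methoxyphenyl on a carbonyl carbon. Among the compounds with values here, no measured step bears on this change: the measured step exchanged one hydroxyphenyl pattern for another, whereas here the hydroxy and methoxy groups leave and a nitro group enters. Within the data shown here, the only plain number is that of compound 1, 29500 nM. Compound 3 is expected to land near that number or somewhat higher, which means an at least 2.0-fold lower number from compound 2 to compound 3 (0.30 log units; that floor lies within the scatter), a move down from the limit. The estimate for compound 3 is 50000 nM, within 15000 nM to 150000 nM.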

Compound 3, half-maximal cytotoxic concentration: > 100000 nM
Compound 3 ended at the assay's limit (the forecaster's own chance of this, stated with the estimate: 35%); middle value at least 2.0-fold (0.30 log units) away from the limit.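

In this assay, compound 3 joins compound 2 at the limit, so a group on the carbonyl carbon need not carry hydroxy or methoxy to reach it. Replacing 2-hydroxyphenyl by 4-nitrophenyl gives an at least 3.3-fold higher number from compound 1 to compound 3 (0.53 log units; beyond the scatter). The step between compound 2 and compound 3 cannot be read, as both values are limits, and the limit now holds most of the series: the limit of > 100000 nM in this assay, at which 2 of the 3 values shown sit.

Going by these compounds alone, compound 1 remains the only compound with a plain number, so the size of any change above the limit stays open. Also open, from the compounds shown here alone, is where a 4-aminophenyl or 4-carboxyphenyl group on the carbonyl carbon would fall.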